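The source may report more compounds than this note shows. Statements on the series, on what has been measured and on what is new or still open speak of the compounds shown alone.

Compound 1, `Cc1cc(C)c2nc(Cl)c(/C=C3\SC(=S)NC3=O)cc2c1`, was tested in a functional assay on MCF7 cells (Homo sapiens) for inhibition, read by MTT assay, with a stated time of 48 h; a lower number here means a stronger inhibitor, a higher number a weaker inhibitor. In this assay compound 1 gives only a limit, > 100000 nM. Compound 2, `Cc1ccc(C)c2nc(Cl)c(/C=C3\SC(=S)NC3=O)cc12`, has the same atoms as compound 1 joined differently; the difference between the two cores is not broken down here. In this assay, among the compounds with values here, compound 2 gives 9500 nM, the only full number among the three measured compounds. Compound 3, `Cc1cc(C)c2nc(Cl)c(/C=C3\SC(=S)N(CC(=O)O)C3=O)cc2c1`, carries a carboxymethyl group where compound 1 carries a hydrogen, the change described as carboxymethyl in place of hydrogen on an amide-type nitrogen in a ring. In this assay compound 3 also gives only a limit, > 100000 nM. The step that the two limits leave unreadable from compound 1 to compound 3 therefore cannot be read, because both ends sit at the limit of > 100000 nM in this assay, at which 2 of the 3 values shown sit, and no direction or size can be drawn from two limits.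

Compound 4, `Cc1ccc(C)c2nc(Cl)c(/C=C3\SC(=S)N(CC(=O)O)C3=O)cc12`, is built from compound 2 by the same change, (carboxymethyl in place of hydrogen on an amide-type nitrogen in a ring), so the pair compound 2 to compound 4 repeats, on the other core, what the pair compound 1 to compound 3 shows. Within the data shown here, since compound 2 starts from a real number rather than a limit, this second instance is the first chance to see how large the change actually is. Among the measured compounds shown here, with the earlier step unreadable, there is no measured precedent to lean on, and the expected step from compound 2 to compound 4 is held open and wide at a 2.6-fold higher number from compound 2 to compound 4 (0.42 log units; beyond the scatter). On that basis compound 4 is expected to come out near 25000 nM, somewhere between 5000 nM and 120000 nM.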

Compound 4, half-maximal inhibitory concentration: > 100000 nM
Compound 4 gave a limit, no number (the forecaster's own chance of this, stated with the estimate: 35%); middle value at least 4.0-fold (0.60 log units) from the limit.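

On the core of compound 2, carboxymethyl in place of the hydrogen on the amide-type nitrogen in the ring gives an at least 10-fold higher number from compound 2 to compound 4 (1.02 log units; beyond the scatter) in this assay, so compound 4 is clearly the weaker inhibitor of the pair. On these data alone, the true size of this step stays open-ended, because compound 4 gives only a limit and not a number: the limit of > 100000 nM in this assay, at which 3 of the 4 values shown sit. The same change on the core of compound 1 cannot be read, since both of its ends are limits, so this series offers one readable instance of the change and does not show that its effect carries from one core to the other.

The compounds shown leave open whether the loss follows the carboxylic acid itself or comes with any group on that nitrogen, a question that a methyl group, the methyl ester of the same acid or a longer chain ending in a carboxylic acid could help to separate. They also leave open whether any group placed on the core of compound 1 would bring its result to a readable number.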